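Methylsulfonyl for methylsulfanyl on the pendant aryl ring

The compounds below may be only part of what the source reports. "The series", "measured", "known", "first", "only" and "open" are said of these compounds alone.

Measured compounds:
compound 1 `CCCC(C)n1c(CC)nc2c(-c3ccc(C(C)(C)O)cc3Cl)ccnc21`, 24 nM
compound 2 `CCCC(C)n1c(CC)nc2c(-c3ccc(OC)cc3C(F)(F)F)ccnc21`, 0.74 nM
compound 3 `CCCC(C)n1c(CC)nc2c(-c3ccc(SC)cc3C(F)(F)F)ccnc21`, 1.4 nM

All three share one core and differ only on the pendant aryl ring. In an assay for binding affinity to Corticotropin releasing factor receptor (Rattus norvegicus) (on this read-out lower numbers stand for stronger inhibition and higher numbers for weaker inhibition), compound 3 gives 1.4 nM, which sets it below compound 1 and close to compound 2; its gap to compound 2 is within the scatter, its gap to compound 1 beyond it. Among the compounds with values here, the only single-point step in the set, a 1.9-fold higher number from compound 2 to compound 3 (0.28 log units; within the scatter), shows that exchanging methoxy for methylsulfanyl leaves the number essentially unchanged.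

Compound 4 `CCCC(C)n1c(CC)nc2c(-c3ccc(S(C)(=O)=O)cc3C(F)(F)F)ccnc21` carries the change (methylsulfonyl in place of methylsulfanyl on an aromatic carbon). Within the data shown here, no measured step covers this exchange directly. Compound 1, which carries a different group at the same place on the ring together with chloro rather than trifluoromethyl, gives 24 nM, far weaker than compound 2 or compound 3; this is only a loose pointer, since two groups differ at once. On balance, the step from compound 3 to compound 4 is expected to move the number upward, estimated at a 21-fold higher number from compound 3 to compound 4 (1.33 log units; beyond the scatter). Compound 4 is therefore expected to give about 30 nM in this assay, with a likely range from 8 nM to 120 nM.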

Compound 4, inhibition constant: 6.8 nM
Estimate against measurement, compound 4: 4.4-fold (0.64 log units) above; the whole stated range lies above it.
By their numbers in this assay, from the lowest: compounds 2 and 3 (each within the scatter of the next); then compound 4; then compound 1.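

In this assay, the change to methylsulfonyl at this ring carbon, meta to a trifluoromethyl group and para to a large group, gives a 4.9-fold higher number from compound 3 to compound 4 (0.69 log units; beyond the scatter), whereas the earlier exchange of methoxy for methylsulfanyl stayed within the scatter. Measured against methoxy, the same group gives a 9.2-fold higher number from compound 2 to compound 4 (0.96 log units; beyond the scatter), so the number at this position does depend on the group it carries, and both steps are modest, leaving compound 4 at 6.8 nM in this series. The compounds shown offer no evidence on why the number rises with this change.

Going by these compounds, whether methylsulfinyl, a sulfonamide or a carboxylic acid at this ring carbon would fall nearer compound 3 or compound 4 stays open, as does the effect of a longer chain on the sulfur, such as ethylsulfonyl. Also open, on these data alone, is whether the methylsulfonyl step would keep its size with chloro in place of trifluoromethyl, since compound 1 differs from the others in two places and cannot settle that.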